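Shortening a Chain Substituent and Its Expected Effect

The source may report more compounds than this note shows. Statements on the series, on what has been measured and on what is new or still open speak of the compounds shown alone.

Compound 1 `CN1CCN(CCNC(=O)n2c(=O)n(Cc3ccccc3)c3ccccc32)CC1` was tested in a functional assay for antagonist activity at 5-hydroxytryptamine receptor 4 (Cavia porcellus); on this read-out higher numbers stand for higher potency (the scale is a negative logarithm) and lower numbers for lower potency. In this assay compound 1 gives only a limit, < 6, not a number. Among the measured compounds shown here, the single numbered result comes from compound 2 `CCCCN1CCN(CCNC(=O)n2c(=O)n(CC)c3ccccc32)CC1`, which in this assay gives 7.73; compound 2 differs from compound 1 in more than one place, so the two values show only that compound 2 is clearly measurable while compound 1 is not. Taken together, the picture so far is the limit of < 6 in this assay, at which 1 of the 2 values shown sits.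

Compound 3 `CCCn1c(=O)n(C(=O)NCCN2CCN(C)CC2)c2ccccc21` has not yet been measured. It differs from compound 1 in one place: ethyl in place of phenyl on a saturated chain carbon bound to an aromatic nitrogen, or benzyl to propyl when the cut is made one bond further out. For the measured compounds named here, no measured pair of compounds shows this exact change. The step expected from this change is a number at least 1.00 log units higher from compound 1 to compound 3 (beyond the scatter), upward and beyond the scatter. Compound 3 is estimated in this assay to reach 7, with a likely range from 6 to 8.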

Compound 3, negative logarithm of the antagonist equilibrium constant: < 6
Compound 3 was reported as a limit; the forecaster's own chance of this, stated with the estimate: 15%; middle value at least 1.00 log units from the limit.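

Compound 1 and compound 3 are both reported only as limits in this assay, so no step can be read between them. The compounds shown leave open whether ethyl in place of phenyl on a saturated chain carbon bound to an aromatic nitrogen changes potency at all, and in which direction.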